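Acetyl in Place of Methyl on the Aromatic Nitrogen

The source may report more compounds than this note shows. Statements on the series, on what has been measured and on what is new or still open speak of the compounds shown alone.

Compound 1 `CNC(=O)N1CCCc2ccc(NC(=O)c3cccc(-c4cnn(C)c4)c3)cc21` stands highest of the two measured compounds in a functional assay on MV4-11 cells (Homo sapiens) for antiproliferative activity, with a stated time of 6 days, tested at 6.25 uM (a higher number here means a stronger effect of the compound at the concentration tested, a lower number a weaker effect), where compound 1 gives 93.5%. Compound 2 `CNC(=O)N1CCCc2ccc(NC(=O)c3ccc(-c4ccccn4)cc3)cc21` gives 79.2% in this assay, and the gap between compound 1 and compound 2 lies beyond the usual scatter. Compound 3 `CNC(=O)N1CCCc2ccc(NC(=O)c3cccc(-c4cnn(C(C)=O)c4)c3)cc21` differs from compound 1 by acetyl in place of methyl on an aromatic nitrogen. Within the data shown here, no measured pair carries this change, so the expectation rests on compound 1 alone, which sits close to full inhibition because compound 1 already gives 93.5%. A small downward step, a number 8.5 percentage points lower from compound 1 to compound 3 (within the scatter), is expected, within the scatter. Compound 3 is expected at 85%, ranging from 62% to 98%.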

Compound 3, a percentage reported as inhibition, at one concentration (the size of the read-out at that concentration, not a potency): 82%
Compound 3: the middle estimate sits 3 percentage points above what was measured, within the range that was stated.
By their numbers in this assay, from the lowest: compounds 2 and 3 (each within the scatter of the next); then compound 1.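

On the aromatic nitrogen of the pyrazole in 1-methyl-1H-pyrazol-4-yl, acetyl in place of methyl gives a modest loss in this assay: a number 11.5 percentage points lower from compound 1 to compound 3 (beyond the scatter). The position still tolerates a larger group carrying a hydrogen-bond acceptor, with compound 3 at 82%. No evidence on the cause of this step is available.

Open, on these data alone, is whether an amine, a carboxylic acid or a longer chain on this nitrogen would hold the inhibition. Also open, as far as these compounds go, is whether the same change gives a similar step on another core.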